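This account rests on a few compounds, and the source may have more. Where it says the series, first, only, none or still open, it means among the compounds named here.

Working notes on the bis(trifluoromethyl)benzenesulfonamide series. Compound 1 `O=S(=O)(NCCCNCc1ccccc1Cl)c1cc(C(F)(F)F)cc(C(F)(F)F)c1` carries 2-chlorophenyl on the saturated chain carbon bound to the amine nitrogen; in a functional assay on MIA PaCa-2 cells (Homo sapiens) for inhibition, read by MTT assay, with a stated time of 72 h (on this read-out higher numbers stand for weaker inhibition of growth and lower numbers for stronger inhibition of growth), compound 1 gives 11000 nM. Compound 2 `COc1ccc(CNCCCNS(=O)(=O)c2cc(C(F)(F)F)cc(C(F)(F)F)c2)cc1OC` replaces that group with 3,4-dimethoxyphenyl, and in this assay compound 2 gives 2800 nM. The step is a 3.9-fold lower number from compound 1 to compound 2 (0.59 log units; beyond the scatter). Going by the values given here, on the two numbers known so far compound 2 holds the lower one, and its gap to compound 1 lies beyond the scatter.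

Compound 3 `O=S(=O)(NCCCNCC1COc2ccccc2O1)c1cc(C(F)(F)F)cc(C(F)(F)F)c1` is not yet measured. Relative to compound 2 the change is 2,3-dihydro-1,4-benzodioxin-2-yl in place of 3,4-dimethoxyphenyl on a saturated chain carbon bound to an amine nitrogen. Among the compounds with values here, the only measured step, from compound 1 to compound 2, bears on this position and was modest in size, so changes here can move the number beyond the scatter. As far as these compounds go, both directions remain open; the unknown leans toward a somewhat higher number for compound 3, since compound 2 is the better of the pair. The expected step is a 1.4-fold higher number from compound 2 to compound 3 (0.15 log units; within the scatter). The estimate for compound 3 in this assay is 4000 nM, with a range from 1500 nM to 12000 nM.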

Compound 3, concentration for 50% growth inhibition: 2600 nM
For compound 3 the middle estimate is 1.5-fold (0.19 log units) above the measured one; the range from low to high includes it.
By their numbers in this assay, from the lowest: compounds 3 and 2 (each within the scatter of the next); then compound 1.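

In this assay the step is a 1.1-fold lower number from compound 2 to compound 3 (0.03 log units; within the scatter), so closing the open 3,4-dimethoxyphenyl into 2,3-dihydro-1,4-benzodioxin-2-yl, with the same heavy-atom and acceptor counts but an added non-aromatic ring, separates the two compounds by nothing the read-out can resolve. The second comparison is a 4.2-fold lower number from compound 1 to compound 3 (0.63 log units; beyond the scatter), which shows that a second group on the saturated chain carbon bound to an amine nitrogen stands clear of 2-chlorophenyl, and that the aromatic ring bound directly at this carbon in compound 2 is not needed to keep its level, since compound 3 carries a non-aromatic ring there. Among these three compounds, the two groups with two oxygens sit together and the chlorine-bearing group stands apart, but nothing measured gives a reason for this grouping.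

Open, as far as these compounds go, is whether the oxygens matter at all, which a plain benzyl or a 4-methoxybenzyl on the same amine nitrogen would test against these values. Also open, from the compounds shown here alone, is how the position responds to a group of another kind, such as a carboxylic acid, a second amine or a longer chain.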